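Halogens change places on the ring of compound 3

A few compounds are considered here, and "the series" means these few. Any claim that something is new, unique, unknown or untested is made for them only; others in the source may bear on it.

For the measured compounds named here, compound 3 `O=C(Nc1cccnc1)c1ccccc1OCc1c(F)cccc1Cl` gives 1500 nM in an assay on lysate for inhibition of phosphatidylcholine:ceramide cholinephosphotransferase 2 (Homo sapiens), read by HPLC, with stated times of 30 min and 2 h (a higher number here means a weaker inhibitor, a lower number a stronger inhibitor), the lowest of the three numbers measured so far. Compound 1 `N#Cc1ccccc1COc1ccccc1C(=O)Nc1cccnc1` gives 31800 nM in this assay, and compound 2 `N#Cc1cccc(COc2ccccc2C(=O)Nc2cccnc2)c1` gives 60700 nM. Between the two cyano compounds the only change is where the nitrile sits, and that gave a 1.9-fold higher number from compound 1 to compound 2 (0.28 log units; within the scatter). Replacing the cyano ring with the chloro-fluoro ring is what sets compound 3 apart: a 21-fold lower number from compound 1 to compound 3 (1.33 log units; beyond the scatter) and a 40-fold lower number from compound 2 to compound 3 (1.61 log units; beyond the scatter).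

Compound 4 `O=C(Nc1cccnc1)c1ccccc1OCc1cccc(Cl)c1F` has the same atoms as compound 3, joined differently: 3-chloro-2-fluorophenyl in place of 2-chloro-6-fluorophenyl on a saturated chain carbon bound to an oxygen on an aromatic ring. Going by the values given here, no measured step moves a halogen around this ring. Among the compounds with values here, the one positional step that is known, between compound 1 and compound 2, stayed within the scatter, whereas the large gains came from the exchange of nitrile for chlorine and fluorine, which compound 4 retains. A small step is therefore expected in this assay, most likely toward a somewhat higher number, though it could fall within the scatter. Compound 4 is estimated to give 3000 nM in this assay, with a range from 800 nM to 12000 nM. That estimate corresponds to an expected step of a 2.0-fold higher number from compound 3 to compound 4 (0.30 log units; within the scatter).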

Compound 4, half-maximal inhibitory concentration: 3100 nM
Beside the measured number, compound 4's estimate is 1.0-fold (0.01 log units) below it; measured number inside the range.
By their numbers in this assay, from the lowest: compound 3; then compound 4; then compounds 1 and 2 (each within the scatter of the next).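

Moving the halogens, with 3-chloro-2-fluorophenyl taking the place of 2-chloro-6-fluorophenyl, gave a 2.1-fold higher number from compound 3 to compound 4 (0.32 log units; beyond the scatter) in this assay and is the first positional change on this ring to step beyond the scatter, though only modestly, so the arrangement of substituents at this place is not wholly indifferent. For the compounds shown here, the rearranged ring still holds a clear lead over both nitrile rings, with a 20-fold lower number from compound 2 to compound 4 (1.29 log units; beyond the scatter) and a 10-fold lower number from compound 1 to compound 4 (1.01 log units; beyond the scatter) as large steps, so the earlier gains do not depend on the one halogen arrangement of compound 3. Across these four compounds, the exchange of nitrile for chlorine and fluorine therefore moves the number further than rearranging those two halogens does.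

The compounds shown leave open whether chlorine or fluorine alone would keep this lead, and how a methoxy group or a second chlorine on this ring would compare with the two halogen arrangements. No measurement given here bears on why either the halogen rearrangement or the loss of the nitrile shifts the number in this way.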